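Chain homologation in a thiazolidinedione benzylidene series

The source may hold more compounds than are shown below. What is called first, only, known or untested is meant among the compounds shown, and "the series" means these compounds.

Working notes on two measured compounds and one awaiting measurement in an assay for inhibition of 15-hydroxyprostaglandin dehydrogenase [NAD(+)] (Homo sapiens), read by spectrophotometry; on this read-out lower numbers stand for stronger inhibition and higher numbers for weaker inhibition. Compound 2 `O=C1N=C(O)S/C1=C\c1ccc(OCCCC2CCCCC2)c(Cl)c1` gives 10 nM. Compound 1 `O=C1N=C(O)S/C1=C\c1ccc(OCCC2CCCCC2)c(Br)c1`, which carries a bromine in place of the chlorine and a shorter chain to the cyclohexyl, gives 19 nM. The two numbers lie within the usual scatter of each other, so neither compound can be set above the other on these data; compound 2 simply sits at the smaller of the two figures. For the measured compounds named here, no pair of measured compounds differs in a single place, so no step has been measured directly.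

Compound 3 `O=C1N=C(O)S/C1=C\c1ccc(OCCCCC2CCCCC2)c(Cl)c1` is the next member: cyclohexylmethyl in place of cyclohexyl on a saturated chain carbon, three bonds along the chain from an oxygen on an aromatic ring. Nothing measured in this assay speaks to lengthening the chain on its own, so the expectation rests on the closeness of compound 2 and compound 1 alone. The step from compound 2 to compound 3 is expected to be a 1.5-fold higher number from compound 2 to compound 3 (0.18 log units; within the scatter), no larger than the scatter. For compound 3 the estimate in this assay is 15 nM, with a range from 5 nM to 45 nM.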

Compound 3, half-maximal inhibitory concentration: 24 nM
Compound 3: middle estimate off by 1.6-fold (0.20 log units), on the low side; the measured number falls inside the stated range.
By their numbers in this assay, from the lowest: compounds 2, 1 and 3 (each within the scatter of the next, the first and the last beyond it).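

Cyclohexylmethyl in place of cyclohexyl on a saturated chain carbon, three bonds along the chain from an oxygen on an aromatic ring, gives a 2.4-fold higher number from compound 2 to compound 3 (0.38 log units; beyond the scatter) in this assay. For the compounds shown here, this is the first step that changes a single place, and it shows that the number at this position responds to the change: modestly, yet beyond the scatter, with the rest of the structure held constant. Nothing available bears on why the number moves at this position.

As far as these compounds go, a single step sets no trend, so it remains open whether 2-cyclohexylethyl in place of cyclohexylmethyl at the same position would extend the change, level off or reverse it, and how a phenyl ring or an ether oxygen in the same region would compare. From the compounds shown here alone, compound 1 differs from compound 2 and from compound 3 in more than one place, so the effect of bromine in place of chlorine remains open, as does the effect of the shorter chain when each is taken alone.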